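Changing the sulfonyl group of compound 3

The compounds below may be only part of what the source reports. "The series", "measured", "known", "first", "only" and "open" are said of these compounds alone.

compound 1 `N#Cc1cc2c(nc1N1CCC(F)(C(=O)NS(=O)(=O)Cc3ccc(Cl)cc3)CC1)COC2=O` gives 37200 nM
compound 2 `CC1(C(=O)NS(=O)(=O)c2ccc(Cl)s2)CCN(c2nc3c(cc2C#N)C(=O)OC3)CC1` gives 1640 nM
compound 3 `Cc1ccc(CS(=O)(=O)NC(=O)C2(F)CCN(c3nc4c(cc3C#N)C(=O)OC4)CC2)cc1` gives 32800 nM

In a functional assay (Platelet, plasma) for inhibition, with Homo sapiens as the target (a higher number here means a weaker inhibitor, a lower number a stronger inhibitor), compound 3 gives 32800 nM and sits level with compound 1 at 37200 nM within the scatter, while compound 2 at 1640 nM stands well below both.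

The next compound, compound 4 `N#Cc1cc2c(nc1N1CCC(F)(C(=O)NS(=O)(=O)c3ccc(Cl)s3)CC1)COC2=O`, carries 5-chlorothiophen-2-yl in place of 4-methylbenzyl on a sulfonyl sulfur.

For the measured compounds named here, only one measured step exists in this small set. Methyl in place of chloro on an aromatic carbon gave a 1.1-fold lower number from compound 1 to compound 3 (0.05 log units; within the scatter) and so made no real difference. That step only alters the group now leaving, so it says little about replacing the whole group. A better guide is compound 2 at 1640 nM. Compound 2 already bears 5-chlorothiophen-2-yl on its sulfonyl sulfur. Going by the values given here, compound 2 also differs from compound 4 elsewhere, and no measured step separates that difference from this one, so the guide is imperfect.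

A clear fall in the number, beyond the scatter, is therefore expected, and the estimated size is a 13-fold lower number from compound 3 to compound 4 (1.12 log units; beyond the scatter) in this reading. The estimate for compound 4 is 2500 nM with an expected range from 700 nM to 9000 nM in this assay.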

Compound 4, half-maximal inhibitory concentration: 37100 nM
For compound 4 the middle estimate is 15-fold (1.17 log units) below the measured one, outside the stated range (above it).
By their numbers in this assay, from the lowest: compound 2; then compounds 3, 4 and 1 (each within the scatter of the next).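

In this assay, changing the sulfonyl group does nothing measurable while the saturated ring carbon carries fluoro: 5-chlorothiophen-2-yl in place of 4-methylbenzyl leaves the result within the scatter (a 1.1-fold higher number from compound 3 to compound 4 (0.05 log units; within the scatter)), and the same holds for 5-chlorothiophen-2-yl in place of 4-chlorobenzyl (a 1.0-fold lower number from compound 1 to compound 4 (0.00 log units; within the scatter)). With 5-chlorothiophen-2-yl held fixed, the large gap appears at a different place, as fluoro in place of methyl on a saturated ring carbon gives a clear rise in the number (a 23-fold higher number from compound 2 to compound 4 (1.35 log units; beyond the scatter)), so the low number of compound 2 depends on its methyl and does not come from its sulfonyl group alone. Nothing available here accounts for why this single ring-carbon change matters so much.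

It remains open whether the sulfonyl group also makes no difference when the ring carbon carries methyl, as compound 2 is the only compound shown with that group. On these data alone, it is also open how a hydroxyl, an ethyl or a plain hydrogen on that ring carbon would compare with fluoro and methyl.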